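The source may report more compounds than this note shows. Statements on the series, on what has been measured and on what is new or still open speak of the compounds shown alone.

Three compounds share one core, differing only in what hangs from its urea nitrogen. Compound 1 `N#CC1CN1C(=O)Nc1ccc(F)cc1` carries a fluoro-substituted aryl group and, in a functional assay on L1210 cells (Mus musculus) for inhibition, read by MTT assay (on this read-out higher numbers stand for weaker inhibition and lower numbers for stronger inhibition), compound 1 gives 7300 nM. Compound 2 `N#CC1CN1C(=O)Nc1ccc(Cl)cc1Cl` carries two chloro groups instead, and in this assay compound 2 gives 207000 nM. Compound 3 `N#CC1CN1C(N)=O`, the bare urea, reaches only a limit of the assay: compound 3 shows > 90000 nM, which is the limit of > 90000 nM in this assay, at which 1 of the 3 values shown sits, rather than a measured number. Compound 1 thus holds the lowest of the two real numbers, with compound 2 a long way beyond the scatter above it.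

Compound 4 `N#CC1CN1C(=O)Nc1ccc(C(F)(F)F)cc1` differs from compound 1 by trifluoromethyl in place of fluoro on an aromatic carbon. Within the data shown here, no measured pair shows this exact change. The only other aryl urea, compound 2 with 207000 nM, leans the expectation toward weaker inhibition for compound 4. The expected step is a 1.6-fold higher number from compound 1 to compound 4 (0.22 log units; within the scatter), a small loss near the edge of the scatter. Compound 4 is therefore estimated at 12000 nM, within 3500 nM to 45000 nM.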

Compound 4, half-maximal inhibitory concentration: 7800 nM
The estimate for compound 4 lay 1.5-fold (0.19 log units) above the measured number; the measured number falls inside the stated range.
By their numbers in this assay, from the lowest: compounds 1 and 4 (each within the scatter of the next); then compound 2.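

Among these compounds, replacing fluoro with trifluoromethyl on this aromatic carbon gives the first step between two compounds that differ in only one place: a 1.1-fold higher number from compound 1 to compound 4 (0.03 log units; within the scatter) in this assay. The two compounds cannot be told apart on this read-out, so on this evidence the position accepts trifluoromethyl, with its 4 heavy atoms, as readily as fluoro, with its 1. Nothing among the data shown accounts for this close match.

Going by these compounds, both groups compared here contain fluorine, so it remains open whether this tolerance extends to a group without fluorine at the same carbon, such as an amine, a carboxylic acid or a longer alkyl chain. On these data alone, it is also open how the number would move with only hydrogen at that carbon.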